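Aryl hydrazide series: step from compound 3 to compound 4

The source may hold more compounds than are shown below. What is called first, only, known or untested is meant among the compounds shown, and "the series" means these compounds.

Compound 1 `Cc1ccc(C(=O)N/N=C/C2=C(Cl)c3ccccc3CCC2)cc1`: 10000 nM
Compound 2 `O=C(N/N=C/C1=C(Cl)c2ccccc2CCC1)c1cccc(I)c1`: 1600 nM
Compound 3 `Cc1cc2c(cc1C)C(Cl)=C(/C=N/NC(=O)c1ccccc1)CCC2`: > 100000 nM

In a functional assay (MiaPaCa cells, Homo sapiens) for inhibition, read by sulforhodamine B assay, with a stated time of 48 h (on this read-out lower numbers stand for stronger inhibition of growth and higher numbers for weaker inhibition of growth), compound 3 gives only a limit, > 100000 nM (the limit of > 100000 nM in this assay, at which 1 of the 3 values shown sits), so no number is known for it. Compound 4 `COc1cccc(C(=O)N/N=C/C2=C(Cl)c3cc(C)c(C)cc3CCC2)c1C` differs from it by 3-methoxy-2-methylphenyl in place of phenyl on a carbonyl carbon. Among the measured compounds shown here, the one measured step of the same kind is an aryl change on a different core: a 6.3-fold lower number from compound 1 to compound 2 (0.80 log units; beyond the scatter), a modest lowering. That step bears only loosely on compound 4, since the shared core of compound 3 carries two methyl groups that compounds 1 and 2 lack, and compound 3 itself sits at the limit. A lowering of similar size is therefore expected, with much uncertainty: compound 4 is estimated at 40000 nM (range 8000 nM to 200000 nM), an expected step of an at least 2.5-fold lower number from compound 3 to compound 4 (0.39 log units; beyond the scatter).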

Compound 4, concentration for 50% growth inhibition: 2000 nM
Compound 4: the middle estimate sits 20-fold (1.30 log units) above what was measured; the whole stated range lies above it.
By their numbers in this assay, from the lowest: compounds 2 and 4 (each within the scatter of the next); then compound 1. At a limit, above all of these: compound 3.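

On the core of compound 3, 3-methoxy-2-methylphenyl in place of phenyl on a carbonyl carbon gives in this assay an at least 50-fold lower number from compound 3 to compound 4 (1.69 log units; beyond the scatter). This large step shows that the group on the carbonyl carbon can decide growth inhibition on this core, beyond the modest change seen on the core of compound 1, a 6.3-fold lower number from compound 1 to compound 2 (0.80 log units; beyond the scatter). Compound 3 stands at a limit, so the full size of the step stays unknown: the limit of > 100000 nM in this assay, at which 1 of the 4 values shown sits.

The compounds shown do not separate the methoxy group from the methyl group in this change. Going by these compounds, whether an amine or a carboxylic acid on the same aromatic ring would keep this inhibition remains open.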